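The source may hold more compounds than are shown below. What is called first, only, known or untested is meant among the compounds shown, and "the series" means these compounds.

Measured compounds, in an assay on isolated protein for inhibition of Rho-associated protein kinase 1 (Homo sapiens), read by scintillation counting, radiometric assay and 33P incorporation, with a stated time of 40 min, in the presence of a further agent that is not named here; a higher number here means a weaker inhibitor, a lower number a stronger inhibitor:

Compound 1 `CN(C)c1ccc(C(=O)Nc2cccc(NC(=O)COc3ccc4c(c3)OCCC4=O)c2)cc1` gives 144 nM.
Compound 2 `Cc1c(OCC(=O)Nc2cccc(NC(=O)c3ccc(N(C)C)cc3)c2)ccc2c(=O)ccoc12` gives > 10000 nM, which is a limit of the assay and not a number.
Compound 3 `CC(C)(C)c1ccc(C(=O)Nc2cccc(NC(=O)COc3ccc4c(=O)ccoc4c3)c2)cc1` gives 165 nM.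

Compound 3 holds the higher of the two numbers obtained in this assay, yet its nearest neighbour, compound 1, sits within the usual scatter of it, so no order between compound 1 and compound 3 can be drawn from these two values. For the measured compounds named here, compound 2 stands apart only as the one value that is a limit (the limit of > 10000 nM in this assay, at which 1 of the 3 values shown sits).

The next compound, compound 4 `O=C(COc1ccc2c(=O)ccoc2c1)Nc1cccc(NC(=O)c2cnc(C(F)(F)F)s2)c1`, keeps the shared core of compound 3 and changes one group: 2-(trifluoromethyl)-1,3-thiazol-5-yl in place of 4-(tert-butyl)phenyl on a carbonyl carbon. Going by the values given here, no measured pair in the set isolates a change of this kind on the amide carbonyl, so the expectation rests on the fact that compound 1 and compound 3, carrying different aryl groups at that position, give numbers within the scatter of each other. A small step is therefore expected, in the direction of a weaker inhibitor if any, with the estimated step of a 2.1-fold higher number from compound 3 to compound 4 (0.33 log units; beyond the scatter). Compound 4 is estimated at 350 nM, within a range from 90 nM to 1500 nM.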

Compound 4, half-maximal inhibitory concentration: 160 nM
Compound 4: middle estimate off by 2.2-fold (0.34 log units), on the high side; low and high end bracket the measured number.
By their numbers in this assay, from the lowest: compounds 1, 4 and 3 (each within the scatter of the next). At a limit, above all of these: compound 2.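

In this assay the amide carbonyl position accepts 2-(trifluoromethyl)-1,3-thiazol-5-yl in place of 4-(tert-butyl)phenyl with no readable change, at a 1.0-fold lower number from compound 3 to compound 4 (0.01 log units; within the scatter) on the shared core. For the compounds shown here, as the only measured pair that differs in one place, it shows that on this carbonyl carbon a five-membered aromatic ring with 2 hetero atoms can stand in for a six-membered aromatic ring of carbon only without any loss beyond the scatter. Nothing measured here accounts for this match between the two groups.

From the compounds shown here alone, whether the same position also holds a group carrying an amine or a carboxylic acid, or a longer chain in place of the ring, remains open. Also open, going by these compounds, is whether this exchange gives the same outcome on the core of compound 1.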